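Working notes: a larger chain substituent on the shared core

The source may hold more compounds than are shown below. What is called first, only, known or untested is meant among the compounds shown, and "the series" means these compounds.

Compound 2 `C/N=C(/S)[C@@]1(c2cccnc2)CCCC[C@@H]1CCOC(C)=O` gives the lowest number of the three measured compounds in a functional assay (aorta) with Rattus norvegicus as the target (a lower number here means a stronger inhibitor, a higher number a weaker inhibitor), at 30 nM. Compound 3 `CNC(=S)[C@@]1(c2cccnc2)CCCC[C@@H]1CCNS(=O)(=O)c1ccc(OC)cc1` gives 300 nM in this assay, a gap beyond the scatter. Compound 1 `C/N=C(/S)C1(c2cccnc2)CCCCC1=O` gives 800 nM in this assay, the furthest from compound 2. Compound 4 `C/N=C(/NCC[C@H]1CCCC[C@@]1(/C(S)=N\C)c1cccnc1)NS(C)(=O)=O` is compound 2 with a group of 9 heavy atoms (3 carbon, 3 nitrogen, 2 oxygen, 1 sulfur; no ring) in place of a group of 4 heavy atoms (2 carbon, 2 oxygen; no ring), on a saturated chain carbon, two bonds along the chain from a saturated ring carbon. Among the measured compounds shown here, no measured pair covers this exact exchange; the nearest guide is compound 3, which also carries a larger group with hydrogen-bond donors in that place. In this assay compound 4 is expected to come out weaker than compound 2, a step of a 6.7-fold higher number from compound 2 to compound 4 (0.82 log units; beyond the scatter) beyond the scatter, because compound 3 gives 300 nM. Compound 4 is estimated at 200 nM, within 60 nM to 800 nM.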

Compound 4, concentration for 90% inhibition: 30 nM
Compound 4: middle estimate off by 6.7-fold (0.82 log units), on the high side, outside the stated range (below it).
By their numbers in this assay, from the lowest: compounds 2 and 4 (each within the scatter of the next); then compound 3; then compound 1.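

In this assay, replacing acetoxy with the larger open-chain group on a saturated chain carbon, two bonds along the chain from a saturated ring carbon, gives no change at the digits printed from compound 2 to compound 4 (within the scatter) and so shows that this place accepts the larger group, with its added hydrogen-bond donors, without a cost in this pair. Size and donor count therefore do not set the number here on their own. Nothing measured here accounts for this result.

Going by these compounds, whether an amine or a carboxylic acid at this place would hold the number remains open. So does the effect of a longer chain between the ring and the end group.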